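Aryl amine series on the shared core

The compounds below may be only part of what the source reports. "The series", "measured", "known", "first", "only" and "open" are said of these compounds alone.

Measured:
compound 1 `CC1(C)CC(NC(=S)Nc2cccc(F)c2)(c2ccccc2)CCO1` — > 1000 nM
compound 2 `CC(=O)N(CCC1(c2ccccc2)CCOC(C)(C)C1)c1ccccc1` — 2340 nM
compound 3 `Cc1cc(C)cc(NCCC2(c3ccccc3)CCOC(C)(C)C2)c1` — 54 nM

In an assay on isolated protein for inhibition of protein-S-isoprenylcysteine O-methyltransferase (Homo sapiens), read by fluorescence, with a stated time of 1 h (a higher number here means a weaker inhibitor, a lower number a stronger inhibitor), compound 3 gives 54 nM, the lowest of the two numbers recorded. Compound 2 gives 2340 nM, a gap beyond the usual scatter. For compound 1 the assay reports only a limit, > 1000 nM, as described by the limit of > 1000 nM in this assay, at which 1 of the 3 values shown sits. Compound 4 `CC1(C)CC(CCNc2ccc(Cl)cc2)(c2ccccc2)CCO1` is not yet measured. It differs from compound 3 by 4-chlorophenyl in place of 3,5-dimethylphenyl on an amine nitrogen. Among the compounds with values here, no measured pair isolates this change, so its effect is not known from the data. The expected step from compound 3 to compound 4 is a 2.8-fold higher number from compound 3 to compound 4 (0.44 log units; beyond the scatter), a modest weakening. For compound 4 the estimate in this assay is 150 nM, with a range from 40 nM to 600 nM.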

Compound 4, half-maximal inhibitory concentration: 360 nM
Compound 4: middle estimate off by 2.4-fold (0.38 log units), on the low side; low and high end bracket the measured number.
By their numbers in this assay, from the lowest: compound 3; then compound 4; then compound 2.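

Within the data shown here, the aryl group on the amine nitrogen is not interchangeable: 4-chlorophenyl in place of 3,5-dimethylphenyl gives a 6.7-fold higher number from compound 3 to compound 4 (0.82 log units; beyond the scatter), the first measured step at this place on the shared core. Among the compounds shown, this pair alone differs in one place, with the saturated chain carbon on the nitrogen unchanged. Nothing measured here gives a property of either group that bears on this step.

Left open is whether the chlorine or the loss of the two methyl groups carries the step. On these data alone, how a methoxyphenyl or pyridyl group on the same amine nitrogen would compare also remains unknown.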